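A few compounds are considered here, and "the series" means these few. Any claim that something is new, unique, unknown or untested is made for them only; others in the source may bear on it.

Measured so far in a functional assay on DU-145 cells (Homo sapiens) for cytotoxicity, read by MTT assay; a higher number here means a weaker inhibitor, a lower number a stronger inhibitor:

compound 1 `CC(C)=CC[C@@H](OC[C@H](C)O)C1=CC(=O)c2c(O)ccc(O)c2C1=O`: 24500 nM
compound 3 `CC(C)=CC[C@@H](OC(=O)CC(C)(O)C(C)C)C1=CC(=O)c2c(O)ccc(O)c2C1=O`: 16900 nM
compound 2 `CCCCCCC(C)(O)CC(=O)O[C@H](CC=C(C)C)C1=CC(=O)c2c(O)ccc(O)c2C1=O`: see below

For compound 2 the result > 100000 nM is a limit of this assay rather than a number. Among the two numbers, compound 1 has the highest, and its nearest neighbour is compound 3: a 1.4-fold lower number from compound 1 to compound 3 (0.16 log units; within the scatter). The other measured step, an at least 5.9-fold lower number from compound 2 to compound 3 (0.77 log units; beyond the scatter), concerns a change elsewhere on the same shared core.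

Compound 4 `CC(C)=CC[C@@H](OC(=O)C1CCCO1)C1=CC(=O)c2c(O)ccc(O)c2C1=O` differs from compound 1 in one place: (oxolan-2-yl)carbonyl in place of 2-hydroxypropyl on an oxygen on a saturated carbon. For the measured compounds named here, of the two measured steps, only the step from compound 1 to compound 3 bears on this change, since it also swapped the 2-hydroxypropyl for a group with a carbonyl on the same oxygen; that step stayed within the scatter. The step from compound 2 to compound 3 altered a different part of the molecule and offers no direct guide. The expectation for compound 4 is therefore a number close to that of compound 1, with no step beyond the scatter expected, a 1.2-fold lower number from compound 1 to compound 4 (0.09 log units; within the scatter). The estimate for compound 4 in this assay is 20000 nM, with a likely range from 8000 nM to 50000 nM.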

Compound 4, half-maximal inhibitory concentration: 10500 nM
The estimate for compound 4 lay 1.9-fold (0.28 log units) above the measured number; measured number inside the range.
By their numbers in this assay, from the lowest: compounds 4, 3 and 1 (each within the scatter of the next, the first and the last beyond it). At a limit, above all of these: compound 2.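

In this assay, (oxolan-2-yl)carbonyl on this oxygen gives the first change from the 2-hydroxypropyl of compound 1 that clears the scatter: a 2.3-fold lower number from compound 1 to compound 4 (0.37 log units; beyond the scatter). Among the groups joined through a carbonyl, swapping 2-hydroxy-2,3-dimethylbutyl for oxolan-2-yl stays inside the scatter, a 1.6-fold lower number from compound 3 to compound 4 (0.21 log units; within the scatter), so these two groups cannot be told apart here. The 2-hydroxy-2-methyloctyl group stands apart, an at least 9.5-fold lower number from compound 2 to compound 4 (0.97 log units; beyond the scatter), a step whose starting point is a limit of the assay rather than a number: the limit of > 100000 nM in this assay, at which 1 of the 4 values shown sits.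

The compounds shown do not settle whether the ring, the carbonyl or the loss of the hydroxyl group accounts for the step away from 2-hydroxypropyl. Going by these compounds, how a plain acetyl group, or a carbonyl group carrying an amine, would compare on this oxygen also remains open.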